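Trading a Fluorophenyl for a Methyl on the Sulfonamide

This account rests on a few compounds, and the source may have more. Where it says the series, first, only, none or still open, it means among the compounds named here.

Measured so far:
- compound 1, `O=S(=O)(Nc1ccc2oc(-c3ccccc3)nc2c1)c1ccccc1F`: 72000 nM
- compound 2, `COc1ccc(S(=O)(=O)Nc2ccc(-c3nc4ccccc4o3)cc2)cc1`: > 100000 nM

Within the data shown here, in an ADME assay on HEK293 cells (Homo sapiens) for cytotoxicity, read by resazurin assay, with a stated time of 48 h (a higher number here means that more compound is tolerated, a lower number that less compound is tolerated), compound 1 gives 72000 nM, the only plain number in the set. Compound 2 reaches only (the limit of > 100000 nM in this assay, at which 1 of the 2 values shown sits), so it is a limit of the assay rather than a number. Among the measured compounds shown here, compound 1 therefore stands alone as the single measured value, with one companion at the limit.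

Compound 3, `CS(=O)(=O)Nc1ccc2oc(-c3ccccc3)nc2c1`, is not yet measured. It differs from compound 1 in one place: methyl in place of 2-fluorophenyl on a sulfonyl sulfur.

For the measured compounds named here, no step between two measured compounds is available to guide the size of this change. Compound 3 is expected to stay close to compound 1, with a step of a 1.2-fold higher number from compound 1 to compound 3 (0.07 log units; within the scatter) not beyond the scatter. The estimate for compound 3 is 85000 nM, in the range 40000 nM to 180000 nM.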

Compound 3, half-maximal cytotoxic concentration: > 100000 nM
Compound 3 ended at the assay's limit; the forecaster's own chance of this, stated with the estimate: 40%; middle value at least 1.1-fold (0.07 log units) from the limit.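

Among these compounds, this is the first readable step at this position: on the sulfonyl sulfur, the whole 2-fluorophenyl ring gives way to a single methyl, and in this assay the change gives an at least 1.3-fold higher number from compound 1 to compound 3 (0.14 log units; that floor lies within the scatter). That floor lies within the scatter, so the step alone does not separate the two compounds, though the real gap may be wider; what it does show is that the much smaller methyl brings no visible loss of tolerance. Two compounds now rest at the same limit, which is a boundary of the assay and not a number: the limit of > 100000 nM in this assay, at which 2 of the 3 values shown sit.

On these data alone, how far compound 3 truly lies past that limit stays unknown, and with it the full size of the step. Also open, as far as these compounds go, is whether a longer chain such as butyl, or an amine such as dimethylamino, on the sulfonyl sulfur would be tolerated as well as methyl.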